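This account rests on a few compounds, and the source may have more. Where it says the series, first, only, none or still open, it means among the compounds named here.

Two compounds with a shared core carry a long flexible chain that ends in an amine, and both have been measured in an assay on isolated protein (Cavia porcellus) with Sigma non-opioid intracellular receptor 1 (Homo sapiens) as the target, read by radioligand binding; a lower number here means a stronger inhibitor, a higher number a weaker inhibitor. Compound 1 `CN(C)CCCCCCCOc1ccc2oc(-c3ccccc3)cc(=O)c2c1` gives 188 nM, and compound 2 `CN(CCCCCCOc1ccc2oc(-c3ccccc3)cc(=O)c2c1)Cc1ccccc1` gives 75 nM, which is the lower of the two numbers. Among the measured compounds shown here, the only step seen so far is a 2.5-fold lower number from compound 1 to compound 2 (0.40 log units; beyond the scatter), a modest gain that came with the benzyl group on the amine.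

Compound 3 `O=c1cc(-c2ccccc2)oc2ccc(OCCCCCCN3CCNC(CCO)C3)cc12` is the next candidate. Its change from compound 2 is 3-(2-hydroxyethyl)piperazin-1-yl in place of benzyl(methyl)amino on a saturated chain carbon, six bonds along the chain from an oxygen on an aromatic ring. For the measured compounds named here, the benzyl group that went with the gain from compound 1 to compound 2 is no longer present, and the ring that enters is of a kind not seen in either measured compound, so no measured step speaks to it directly. With the benzyl group gone, the expectation is that compound 3 drifts back toward where compound 1 stood, an expected step of a 3.3-fold higher number from compound 2 to compound 3 (0.52 log units; beyond the scatter) in this assay, with the range kept wide. Compound 3 is therefore estimated at 250 nM, between 60 nM and 1000 nM.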

Compound 3, half-maximal inhibitory concentration: 94 nM
Beside the measured number, compound 3's estimate is 2.7-fold (0.42 log units) above it, and the stated range covers the measured number.
By their numbers in this assay, from the lowest: compounds 2, 3 and 1 (each within the scatter of the next, the first and the last beyond it).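

In this assay, 3-(2-hydroxyethyl)piperazin-1-yl in place of benzyl(methyl)amino gives a 1.3-fold higher number from compound 2 to compound 3 (0.10 log units; within the scatter). The two groups therefore cannot be told apart here, which shows that this chain position does not depend on a six-membered aromatic ring of carbon only: a non-aromatic ring with two hetero atoms and added hydrogen-bond donors serves within the scatter. The other comparison, a 2.0-fold lower number from compound 1 to compound 3 (0.30 log units; within the scatter), also lies within the scatter, so compound 3 cannot be separated from either neighbour even though the step from compound 1 to compound 2 lies beyond it, and no outside information on these compounds explains this result.

The compounds shown do not tell whether the 2-hydroxyethyl group contributes anything, since a plain piperazin-1-yl group or a morpholine ring at the same place would be needed to separate the hydroxyl and the second ring nitrogen from the ring itself. They also leave open how the 3-(2-hydroxyethyl)piperazin-1-yl group would behave on a shorter or longer chain, and whether a benzyl group on the piperazine nitrogen would add to it.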